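Series notes: amide nitrogen substituent, compound 2 to compound 3

This account rests on a few compounds, and the source may have more. Where it says the series, first, only, none or still open, it means among the compounds named here.

Measured so far:
compound 1 `Cc1ccc(CNC(=O)c2[nH]cnc2C(=O)Nc2ccc(Cl)c(Cl)c2)cc1`: 21400 nM
compound 2 `COc1ccc(CNC(=O)c2[nH]cnc2C(=O)Nc2ccc(Cl)c(Cl)c2)cc1`: 24300 nM

In a functional assay on HL-60 cells (Homo sapiens), with a stated time of 2 days (a higher number here means a weaker inhibitor, a lower number a stronger inhibitor), compound 1 gives 21400 nM and compound 2 gives 24300 nM. Compound 2 holds the highest of the two numbers, but the step of a 1.1-fold higher number from compound 1 to compound 2 (0.06 log units; within the scatter) lies within the scatter, so the two compounds are not separated. Compound 3 `COC(=O)[C@@H](NC(=O)c1[nH]cnc1C(=O)Nc1ccc(Cl)c(Cl)c1)C(C)C` differs from compound 2 by 1-(methoxycarbonyl)-2-methylpropyl in place of 4-methoxybenzyl on an amide-type nitrogen. Within the data shown here, no measured step touches this amide nitrogen substituent; the single known step concerns only the aromatic substituent and gives no guidance on the size or direction here. The expectation is therefore no step beyond the scatter, with wide uncertainty. Compound 3 is estimated at 25000 nM (range 7000 nM to 90000 nM), an expected step of a 1.0-fold higher number from compound 2 to compound 3 (0.01 log units; within the scatter).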

Compound 3, half-maximal inhibitory concentration: > 62500 nM
Compound 3 gave a limit, no number; the forecaster's own chance of this, stated with the estimate: 20%; at least 2.5-fold (0.39 log units) between middle value and limit.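

Putting 1-(methoxycarbonyl)-2-methylpropyl on the amide-type nitrogen gives an at least 2.5-fold higher number from compound 2 to compound 3 (0.41 log units; beyond the scatter) and an at least 2.9-fold higher number from compound 1 to compound 3 (0.46 log units; beyond the scatter) in this assay, so this position, unlike the aromatic substituent of the benzyl group, moves the read-out beyond the scatter. Compound 3 gives a limit and no number: the limit of > 62500 nM in this assay, at which 1 of the 3 values shown sits.

The change removes the aromatic ring and brings in the methoxycarbonyl group together, and the compounds shown do not separate the two. Also open, on these data alone, is how a phenethyl group, or a carboxylic acid in place of the methoxycarbonyl group, would read at this nitrogen.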